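Methyl for Chloro on the Aryl Ring of Compound 3

A few compounds are considered here, and "the series" means these few. Any claim that something is new, unique, unknown or untested is made for them only; others in the source may bear on it.

Measured compounds:
compound 1 `Cc1ccc(-c2cs/c(=N/NC(=O)CSc3nncn3C)n2-c2ccccc2)cc1`, 72%
compound 2 `Cc1ccc(-c2cs/c(=N/NC(=O)CSc3nnnn3C)n2-c2ccccc2)cc1`, 68.8%
compound 3 `O=C(CSc1ncccn1)N/N=c1/scc(-c2ccc(Cl)cc2)n1-c1ccccc1`, 91.6%

In a functional assay on C6 cells (Rattus norvegicus) for cytotoxicity, read by MTT assay, with a stated time of 24 h, tested at 12 ug/mL (on this read-out higher numbers stand for a weaker effect at the one concentration tested and lower numbers for a stronger effect), compound 3 gives the highest of the three numbers, that is the weakest effect; compound 1 stands nearest to it and compound 2 furthest, both beyond the scatter. Compound 4 `Cc1ccc(-c2cs/c(=N/NC(=O)CSc3ncccn3)n2-c2ccccc2)cc1` is not yet measured. It differs from compound 3 in one place: methyl in place of chloro on an aromatic carbon.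

Among the measured compounds shown here, only one measured step exists, a number 3.2 percentage points lower from compound 1 to compound 2 (within the scatter), and it changes the heterocycle on the sulfur, not the aryl ring; it therefore does not bear on the move from compound 3 to compound 4. Compounds 1 and 2, which carry the methyl-substituted ring, differ from compound 3 in the heterocycle as well, so their values cannot be read as the effect of the ring change alone. For the measured compounds named here, with no direct precedent, the change in this assay is expected to be modest, tending toward the values of compounds 1 and 2: for compound 4 the expected step is a number 9.6 percentage points lower from compound 3 to compound 4 (within the scatter). Compound 4 is thus estimated at 82%, within 65% to 96%.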

Compound 4, a percentage reported as activity, at one concentration (the size of the read-out at that concentration, not a potency): 83%
Beside the measured number, compound 4's estimate is 1 percentage points below it; the measured number falls inside the stated range.
By their numbers in this assay, from the lowest: compounds 2 and 1 (each within the scatter of the next); then compounds 4 and 3 (each within the scatter of the next).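

In this assay, the change from 4-chlorophenyl to 4-methylphenyl can now be read directly: a number 8.6 percentage points lower from compound 3 to compound 4 (within the scatter), so the two compounds cannot be told apart at this aromatic carbon. With the 4-methylphenyl ring held fixed, the group on the sulfur can also be read, as a number 14.2 percentage points higher from compound 2 to compound 4 (beyond the scatter) and a number 11 percentage points higher from compound 1 to compound 4 (beyond the scatter); pyrimidin-2-yl thus goes with a weaker effect at the one concentration tested than either 1-methyl-1H-tetrazol-5-yl or 4-methyl-4H-1,2,4-triazol-3-yl. Nothing measured here offers a reason for either result.

The compounds shown leave open whether a methoxy group or an amine on the same aromatic carbon would also stay within the scatter of compound 3. They also leave open whether chloro and methyl would remain indistinguishable with 1-methyl-1H-tetrazol-5-yl on the sulfur.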